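A few compounds are considered here, and "the series" means these few. Any claim that something is new, unique, unknown or untested is made for them only; others in the source may bear on it.

In a functional assay on HL-60 cells (Homo sapiens) for cytotoxicity, read by CCK-8 assay, with a stated time of 24 h (on this read-out lower numbers stand for stronger inhibition and higher numbers for weaker inhibition), the three measured compounds gave these values:

compound 1, `C=CC(=O)N1C(=O)CC(c2ccc(OC)cc2)Sc2ccccc21`: 92100 nM
compound 2, `C=CC(=O)N1C(=O)CC(c2ccc(Br)cc2)Sc2ccccc21`: 126000 nM
compound 3, `C=CC(=O)N1C(=O)CC(c2cccs2)Sc2ccccc21`: 695000 nM

Compound 2 holds the second highest of the three numbers. Its nearest neighbour is compound 1, and the step of a 1.4-fold higher number from compound 1 to compound 2 (0.14 log units; within the scatter) lies within the scatter, so the two cannot be told apart. Its furthest neighbour is compound 3, reached by a 5.5-fold higher number from compound 2 to compound 3 (0.74 log units; beyond the scatter); the related step of a 7.5-fold higher number from compound 1 to compound 3 (0.88 log units; beyond the scatter) points the same way.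

Compound 4, `C=CC(=O)N1C(=O)CC(c2ccc(C#N)cc2)Sc2ccccc21`, differs from compound 2 by cyano in place of bromo on an aromatic carbon. Of the measured steps, only the change from compound 1 to compound 2 resembles it, as it also swaps one group for another on the same aromatic carbon, and that step stayed within the scatter. The two steps involving compound 3 replace the whole aryl ring and do not bear on this exchange. Compound 4 is therefore expected to show no step beyond the scatter, a 1.1-fold lower number from compound 2 to compound 4 (0.02 log units; within the scatter). The estimate for compound 4 is 120000 nM, with a range from 50000 nM to 300000 nM.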

Compound 4, half-maximal inhibitory concentration: 115000 nM
For compound 4 the middle estimate is 1.0-fold (0.02 log units) above the measured one; the range from low to high includes it.
By their numbers in this assay, from the lowest: compounds 1, 4 and 2 (each within the scatter of the next); then compound 3.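

In this assay, the exchange of 4-bromophenyl for 4-cyanophenyl gave a 1.1-fold lower number from compound 2 to compound 4 (0.04 log units; within the scatter), and cyano in place of methoxy gave a 1.2-fold higher number from compound 1 to compound 4 (0.10 log units; within the scatter), so the three groups tried on this aromatic carbon, para to a large group, cannot be told apart. The thiophen-2-yl compound stays clearly separate from this third substituted phenyl compound as well, with a 6.0-fold lower number from compound 3 to compound 4 (0.78 log units; beyond the scatter), so compounds 1, 2 and 4 now form one group with compound 3 outside it. No evidence is available on what lies behind either result.

The compounds shown leave open whether an amine or a carboxylic acid on the same aromatic carbon would also stay within the scatter of these three. They also leave open whether a thiophen-2-yl ring carrying a bromo or cyano group would close the gap to the phenyl compounds.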